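The source may report more compounds than this note shows. Statements on the series, on what has been measured and on what is new or still open speak of the compounds shown alone.

Compound 2, `CCc1ccc2[nH]c(=O)c(CN(Cc3ccc(F)cc3)Cc3ccc4ccccc4c3)cc2c1`, carries a naphthalen-2-yl group on a saturated chain carbon bound to an amine nitrogen. In a toxicity assay on MDCK cells (Canis lupus familiaris) for cytotoxicity, read by crystal violet staining, with a stated time of 48 h (on this read-out higher numbers stand for lower toxicity in this test and lower numbers for higher toxicity in this test), compound 2 reaches only a limit, > 5000 nM. Compound 1, `CCc1ccc(CN(Cc2ccc(F)cc2)Cc2cc3ccc(C)cc3[nH]c2=O)cc1`, also gives only a limit, > 33000 nM. Compound 3, `CCc1ccc2[nH]c(=O)c(CN(Cc3cccc(F)c3)Cc3ccc4ccccc4c3)cc2c1`, likewise stops at a limit, > 5000 nM. The step that the two limits leave unreadable from compound 2 to compound 3 therefore cannot be read, since both ends rest on (the limit of > 5000 nM in this assay, at which 2 of the 3 values shown sit). Compound 4, `CCc1ccc2[nH]c(=O)c(CN(Cc3ccc(F)cc3)Cc3ccc(-c4ccccc4)cc3)cc2c1`, differs from compound 2 by 4-phenylphenyl in place of naphthalen-2-yl on a saturated chain carbon bound to an amine nitrogen. Among the measured compounds shown here, no measured step bears directly on a change of this kind, and every value shown sits at a limit, one at the limit of > 33000 nM in this assay, at which 1 of the 3 values shown sits, and two at the limit of > 5000 nM in this assay, at which 2 of the 3 values shown sit. Compound 4 is therefore expected to give a step that the limit leaves unreadable from compound 2 to compound 4 that is itself unreadable, and its estimated value is 20000 nM, between 5000 nM and 100000 nM.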

Compound 4, half-maximal cytotoxic concentration: > 5000 nM
Compound 4 gave a limit, no number; the forecaster's own chance of this, stated with the estimate: 80%; the middle value does not contradict the limit.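

Like compound 2, compound 4 gives only a limit in this assay, > 5000 nM, and the step between these two compounds cannot be read. The compounds shown leave open where any of their actual cytotoxic concentrations lies.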